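Swapping an Acetyl for a Methyl on a Fused Ring Core

The compounds below may be only part of what the source reports. "The series", "measured", "known", "first", "only" and "open" are said of these compounds alone.

Of the compounds shown here, three built on one shared core have been tested in an ADME assay on RAW264.7 cells (Mus musculus) for cytotoxicity, read by MTT assay, with a stated time of 48 h, tested at 50 uM; on this read-out higher numbers stand for more inhibition at the one concentration tested (going by the name of the read-out) and lower numbers for less inhibition. Compound 1 `CC(=O)N1CCc2c(sc(NC(=O)c3ccc(Oc4ccccc4)cc3)c2C(N)=O)C1` gives 32.9%. Compound 2 `CN1CCc2c(sc(NC(=O)c3ccc(Oc4ccccc4)cc3)c2C(N)=O)C1` gives 58.9% in this assay, and compound 3 `CC(=O)N1CCc2c(sc(NC(=O)c3ccc(OCc4ccccc4)cc3)c2C(N)=O)C1` gives 11.6%. The change from compound 1 to compound 2 is methyl in place of acetyl on an amine nitrogen in a ring and brings a number 26 percentage points higher from compound 1 to compound 2 (beyond the scatter). The change from compound 1 to compound 3 is benzyl in place of phenyl on an oxygen on an aromatic ring, which is how the core of compound 3 differs from the core of compound 1, and it brings a number 21.3 percentage points lower from compound 1 to compound 3 (beyond the scatter); compound 3 stands lowest of the three in this assay.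

Compound 4 `CN1CCc2c(sc(NC(=O)c3ccc(OCc4ccccc4)cc3)c2C(N)=O)C1` has not yet been measured. Among the measured compounds shown here, it differs from compound 3 by methyl in place of acetyl on an amine nitrogen in a ring, the same change at the same place as the one that turns compound 1 into compound 2. If that change carries over onto the core of compound 3, compound 4 is expected to show a step of a number 24.4 percentage points higher from compound 3 to compound 4 (beyond the scatter) in this assay, set beside the earlier a number 26 percentage points higher from compound 1 to compound 2 (beyond the scatter) and resting on compound 3 at 11.6%. Compound 4 is therefore estimated at 36% in this assay, between 16% and 56%, with a single example of this change behind the guess.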

Compound 4, a percentage reported as inhibition, at one concentration (the size of the read-out at that concentration, not a potency): 37.6%
Compound 4: the middle estimate sits 1.6 percentage points below what was measured; the measured number falls inside the stated range.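

In this assay, methyl in place of acetyl on the amine nitrogen in a ring again raises the number, giving a number 26 percentage points higher from compound 3 to compound 4 (beyond the scatter), and this matches the earlier step: the same change on two cores in this assay, a number 26 percentage points higher (beyond the scatter) from compound 1 to compound 2 and a number 26 percentage points higher (beyond the scatter) from compound 3 to compound 4, 0 percentage points apart, within the scatter of two such steps Benzyl in place of phenyl on the oxygen gives a number 21.3 percentage points lower from compound 2 to compound 4 (beyond the scatter), and this too repeats an earlier step: the same change on two cores in this assay, a number 21.3 percentage points lower (beyond the scatter) from compound 1 to compound 3 and a number 21.3 percentage points lower (beyond the scatter) from compound 2 to compound 4, 0 percentage points apart, within the scatter of two such steps Across these four compounds, each change therefore carries over from one core to the other with no sign that either alters the other's step, but this rests on one repeat of each change at a single concentration and does not show why the steps match or whether they would hold on a different core.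

The compounds shown carry only acetyl or methyl on that nitrogen, and only phenyl or benzyl on the oxygen. Going by these compounds, whether an ethyl group on the nitrogen, or a longer chain such as phenylethyl on the oxygen, would follow the same steps remains open.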